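A few compounds are considered here, and "the series" means these few. Any claim that something is new, unique, unknown or untested is made for them only; others in the source may bear on it.

Measured in a functional assay on BGC-823 cells (Homo sapiens) for antiproliferative activity, read by MTT assay, with a stated time of 24 h; on this read-out higher numbers stand for weaker inhibition and lower numbers for stronger inhibition:
- compound 1 `Clc1ccccc1CSc1nnc(-c2ccc3c(c2)OCCO3)n1-c1ccccc1`: 17400 nM
- compound 2 `Brc1ccccc1CSc1nnc(-c2ccc3c(c2)OCCO3)n1-c1ccccc1`: > 100000 nM

Compound 2 stands at > 100000 nM, which is a limit of the assay and not a number. Compound 3 `Brc1ccc(CSc2nnc(-c3ccc4c(c3)OCCO4)n2-c2ccccc2)cc1` has the same atoms joined differently: 4-bromophenyl in place of 2-bromophenyl on a saturated chain carbon bound to a sulfur. Among the compounds with values here, no measured step tests this shift directly. Within the data shown here, the nearest is an at least 5.7-fold higher number from compound 1 to compound 2 (0.75 log units; beyond the scatter), which shows only that one change on that aromatic ring can go beyond the scatter. In this assay a modest step toward a lower number is therefore expected, though compound 3 may also stay at the limit. The expected size of the change is an at least 2.0-fold lower number from compound 2 to compound 3 (0.30 log units; that floor lies within the scatter). The estimate for compound 3 is 50000 nM, with a range from 15000 nM to 100000 nM.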

Compound 3, half-maximal inhibitory concentration: 33800 nM
For compound 3 the middle estimate is 1.5-fold (0.17 log units) above the measured one, within the range that was stated.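

In this assay, 4-bromophenyl in place of 2-bromophenyl on a saturated chain carbon bound to a sulfur gives an at least 2.9-fold lower number from compound 2 to compound 3 (0.47 log units; beyond the scatter), so with the same atoms, where the bromine sits on this ring changes the result. Compound 2 counts only as a limit of the assay, not a number: the limit of > 100000 nM in this assay, at which 1 of the 3 values shown sits.

Replacing 2-chlorophenyl with 4-bromophenyl gives a 1.9-fold higher number from compound 1 to compound 3 (0.29 log units; within the scatter), so that pair cannot be told apart.

Still open, from the compounds shown here alone, is how 3-bromophenyl or 4-chlorophenyl would behave at this place. Also open, going by these compounds, is whether an amine or a carboxylic acid on this ring would give a lower number.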